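The source may hold more compounds than are shown below. What is called first, only, known or untested is meant among the compounds shown, and "the series" means these compounds.

Compound 1 `CO[C@H]1C(=O)N2C(C(=O)C(C)(C)C)=C(CSc3nnnn3C)CS(=O)(=O)C12` gives 24 h in a physicochemical assay, at pH 7.4; a lower number here means that the compound disappears faster, a higher number that the compound lasts longer.
Compound 2 `CO[C@H]1C(=O)N2C(C(=O)c3ccccc3)=C(CSc3nnnn3C)CS(=O)(=O)C12` gives 17 h in this assay.

Within the data shown here, compound 2 holds the lower of the two numbers in this assay, with compound 1 its only neighbour; the one measured step, a 1.4-fold lower number from compound 1 to compound 2 (0.15 log units; within the scatter), is a phenyl in place of tert-butyl on a carbonyl carbon and lies within the scatter.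

Compound 3 `CO[C@H]1C(=O)N2C(C(=O)c3ccccc3)=C(CSc3nnnn3C)[C@@H](Sc3nnnn3C)S(=O)(=O)C12` is compound 2 with one addition: (1-methyl-1H-tetrazol-5-yl)sulfanyl in place of hydrogen on a saturated ring carbon. Among the measured compounds shown here, no measured step touches this saturated ring carbon, so nothing among the measured compounds bears directly on the change; the sole step seen, a 1.4-fold lower number from compound 1 to compound 2 (0.15 log units; within the scatter), concerns a different part of the core and does not reach beyond the scatter. For compound 3 the expectation in this assay is therefore a number near that of compound 2, with a wide range, estimated at 12 h (from 4 h to 30 h), a step of a 1.4-fold lower number from compound 2 to compound 3 (0.15 log units; within the scatter) that is itself expected to stay within the scatter.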

Compound 3, half-life: 1400 h
Compound 3: the middle estimate sits 120-fold (2.07 log units) below what was measured; measured number outside the range, above it.
By their numbers in this assay, from the lowest: compounds 2 and 1 (each within the scatter of the next); then compound 3.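

In this assay, the saturated ring carbon next to the ring sulfur proves to be a far more sensitive place than the carbonyl carbon: (1-methyl-1H-tetrazol-5-yl)sulfanyl in place of hydrogen there gives an 82-fold higher number from compound 2 to compound 3 (1.92 log units; beyond the scatter). Among these compounds, this is the only step so far to go beyond the scatter, whereas the change on the carbonyl carbon gave a 1.4-fold lower number from compound 1 to compound 2 (0.15 log units; within the scatter). Nothing shown accounts for the size of this gain.

The compounds shown leave open whether the gain belongs to this particular group or would also come with a smaller one at the same carbon, such as methyl, methylsulfanyl or an amine. They also leave open whether the same addition would act alike with tert-butyl on the carbonyl carbon, as in compound 1.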